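The source may report more compounds than this note shows. Statements on the series, on what has been measured and on what is new or still open speak of the compounds shown alone.

Measured in a functional assay on K562 cells (Homo sapiens) for antiproliferative activity, read by CellTiter-Glo, with a stated time of 72 h; a lower number here means that less compound is needed, a higher number that more compound is needed for the effect:
- compound 1 `CC(C)(C)CC(C)(C)Nc1ncnc2c1ncn2[C@@H]1O[C@H](COS(N)(=O)=O)[C@@H](O)[C@H]1O`: > 1000 nM, a limit
- compound 2 `CCC(C)Nc1ncnc2c1ncn2[C@@H]1O[C@H](COS(N)(=O)=O)[C@@H](O)[C@H]1O`: > 1000 nM, a limit
- compound 3 `CCCCCC(C)Nc1ncnc2c1ncn2[C@@H]1O[C@H](COS(N)(=O)=O)[C@@H](O)[C@H]1O`: 203 nM

Going by the values given here, compound 3 gives the only actual number of the three. Compound 1 and compound 2 sit at the limit of > 1000 nM in this assay, at which 2 of the 3 values shown sit.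

The next step leads to compound 4 `CN(Cc1ccco1)c1ncnc2c1ncn2[C@@H]1O[C@H](COS(N)(=O)=O)[C@@H](O)[C@H]1O`: ((furan-2-yl)methyl)(methyl)amino in place of (1-methylhexyl)amino on an aromatic carbon, on an aromatic carbon of the shared core. Two measured steps change this same substituent: an at least 4.9-fold lower number from compound 1 to compound 3 (0.69 log units; beyond the scatter) and an at least 4.9-fold lower number from compound 2 to compound 3 (0.69 log units; beyond the scatter). Both are open-ended, and a step that the two limits leave unreadable from compound 1 to compound 2 adds nothing readable. Among the compounds with values here, no measured step tests a five-membered aromatic ring here.

Within the data shown here, with compound 3 at 203 nM the only member giving a number, a higher number is expected in this assay. The expected step is a 5.9-fold higher number from compound 3 to compound 4 (0.77 log units; beyond the scatter). The estimate for compound 4 is 1200 nM, with an expected range of 250 nM to 5000 nM.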

Compound 4, half-maximal effective concentration: > 1000 nM
Compound 4: only a limit was reported (the forecaster's own chance of this, stated with the estimate: 55%); the middle value is on the limit's open side.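

In this assay, ((furan-2-yl)methyl)(methyl)amino in place of (1-methylhexyl)amino gives an at least 4.9-fold higher number from compound 3 to compound 4 (0.69 log units; beyond the scatter), so matching the heavy-atom count of the group that leaves does not keep the number of compound 3. The steps from compound 1 and compound 2 to compound 4 cannot be read, and the only number in the set remains that of compound 3: the limit of > 1000 nM in this assay, at which 3 of the 4 values shown sit.

The step adds the furan ring and removes the amine hydrogen together, and the two changes cannot be separated here. As far as these compounds go, a (furan-2-yl)methylamino group, which keeps that hydrogen, or a longer chain such as 1-methylheptyl remains open.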